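Adding a second methyl where a chlorine once stood

This account rests on a few compounds, and the source may have more. Where it says the series, first, only, none or still open, it means among the compounds named here.

The shared core, seen in compound 1 `O=C(Nc1ccc(Cl)cc1)Nc1cccc(CNc2nccnc2Cl)c1`, carries a urea-type linkage to a substituted phenyl ring. Among the measured compounds shown here, in a functional assay on MGC-803 cells (Homo sapiens) for antiproliferative activity, read by MTT assay, with a stated time of 48 h (on this read-out higher numbers stand for weaker inhibition and lower numbers for stronger inhibition), compound 1 gives 4980 nM, the lowest of the two numbers measured so far. Compound 2 `O=C(Nc1cccc(Cl)c1)Nc1cccc(CNc2nccnc2Cl)c1` is its nearest neighbour; compound 2 gives 5330 nM in this assay, and the step of a 1.1-fold higher number from compound 1 to compound 2 (0.03 log units; within the scatter) shows that 3-chlorophenyl in place of 4-chlorophenyl changes little. Compound 3 `Cc1ccc(NC(=O)Nc2cccc(CNc3nccnc3Cl)c2)c(C)c1` has not yet been measured. It differs from compound 1 by 2,4-dimethylphenyl in place of 4-chlorophenyl on an amide-type nitrogen. For the measured compounds named here, no measured step exchanges the chlorine for methyl groups, so the only guide is the step from compound 1 to compound 2, which stayed within the scatter. On that basis the change to compound 3 is expected to bring no step beyond the scatter, a 1.0-fold higher number from compound 1 to compound 3 (0.00 log units; within the scatter). Compound 3 is therefore estimated at 5000 nM in this assay, within a range from 2500 nM to 11000 nM.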

Compound 3, half-maximal inhibitory concentration: 10100 nM
Beside the measured number, compound 3's estimate is 2.0-fold (0.31 log units) below it; the range from low to high includes it.
By their numbers in this assay, from the lowest: compounds 1, 2 and 3 (each within the scatter of the next, the first and the last beyond it).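

Among the compounds shown here, exchanging the single chlorine for two methyl groups is the first change on this amide-type nitrogen to pass the scatter in this assay and gives a 2.0-fold higher number from compound 1 to compound 3 (0.31 log units; beyond the scatter) as a modest step. With 3-chlorophenyl as the starting point, the same 2,4-dimethylphenyl group gives a 1.9-fold higher number from compound 2 to compound 3 (0.28 log units; within the scatter) and stays within the scatter, so whether this exchange registers at all depends on which chlorophenyl it replaces. Nothing at hand accounts for the step.

The two methyl groups enter together, so the compounds shown leave open whether a single methyl on the phenyl ring would give a similar number. They also leave open how a methoxy group, an amine or a carboxylic acid on that ring would compare.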